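A few compounds are considered here, and "the series" means these few. Any claim that something is new, unique, unknown or untested is made for them only; others in the source may bear on it.

Compound 1 `O=C(CSc1nc(Nc2ccccc2)c2ccccc2n1)Nc1cccc(Br)c1`: 10100 nM
Compound 2 `O=C(CSc1nc(Nc2ccccc2)c2ccccc2n1)Nc1cccc([N+](=O)[O-])c1`: 17900 nM

Both were tested in a functional assay on NCI-H1975 cells (Homo sapiens) for inhibition, read by MTT assay, with a stated time of 72 h; a higher number here means a weaker inhibitor, a lower number a stronger inhibitor. Compound 1 sits at one end of a pair of numbers that the scatter does not separate, since the step to compound 2 is only a 1.8-fold higher number from compound 1 to compound 2 (0.25 log units; within the scatter). Compound 3 `O=C(CSc1nc(Nc2ccccc2)c2ccccc2n1)Nc1ccc([N+](=O)[O-])cc1` is the next variation: 4-nitrophenyl in place of 3-bromophenyl on an amide-type nitrogen. Among the compounds with values here, the single step that bears on it, swapping bromo for nitro on that ring, stayed within the scatter, so no change beyond the scatter is expected for compound 3, an expected step of a 1.5-fold higher number from compound 1 to compound 3 (0.17 log units; within the scatter). Compound 3 is therefore estimated at 15000 nM, within a range of 6000 nM to 40000 nM.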

Compound 3, half-maximal inhibitory concentration: 13000 nM
Beside the measured number, compound 3's estimate is 1.2-fold (0.06 log units) above it; measured number inside the range.
By their numbers in this assay, from the lowest: compounds 1, 3 and 2 (each within the scatter of the next).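

In this assay, 4-nitrophenyl in place of 3-nitrophenyl on the amide-type nitrogen does not separate the two compounds (a 1.4-fold lower number from compound 2 to compound 3 (0.14 log units; within the scatter)), so the place of the nitro group on this ring makes no readable difference here. 4-Nitrophenyl in place of 3-bromophenyl is equally unresolved (a 1.3-fold higher number from compound 1 to compound 3 (0.11 log units; within the scatter)), leaving compound 1, compound 2 and compound 3 together within the scatter. No evidence is available to explain this. Still open, as far as these compounds go, is whether an amine or a carboxylic acid on this ring would shift the number beyond the scatter.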